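Swapping methylsulfonyl for tert-butyl on the shared core

The source may hold more compounds than are shown below. What is called first, only, known or untested is meant among the compounds shown, and "the series" means these compounds.

Measured in a physicochemical assay for lipophilicity, read by HPLC, measured as chromatographic lipophilicity, at pH 7.4; a higher number here means a more lipophilic compound, a lower number a more polar compound:
- compound 1 `Cc1ccc(C2CC=NN2C(=O)C(C)(C)C)cc1`: 6.4
- compound 2 `CC(C)(C)C(=O)N1CCNCC1c1ccccc1`: 2.5
- compound 3 `CC(C)(C)C(=O)N1N=CCC1c1ccc(S(C)(=O)=O)cc1`: 4.1

Compound 3 sits in the middle of the three, above compound 2 and below compound 1. The next compound, compound 4 `CC(C)(C)C(=O)N1N=CCC1c1ccc(C(C)(C)C)cc1`, carries tert-butyl in place of methylsulfonyl on an aromatic carbon. Within the data shown here, one measured step bears on this change: a number 2.30 log units lower from compound 1 to compound 3 (beyond the scatter), a large drop, with methylsulfonyl in place of methyl at that same spot. Compound 4 removes that methylsulfonyl, so a large rise in this assay is expected, somewhat beyond that drop, since tert-butyl is a bigger all-carbon group than methyl. Among the measured compounds shown here, no tert-butyl compound has been measured yet. The expected size of the rise is a number 3.10 log units higher from compound 3 to compound 4 (beyond the scatter). For compound 4 the estimate is 7.2, with an expected range of 6.5 to 7.9.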

Compound 4, distribution coefficient: 8
Estimate against measurement, compound 4: 0.80 log units below; measured number outside the range, above it.
By their numbers in this assay, from the lowest: compound 2; then compound 3; then compound 1; then compound 4.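

Placing tert-butyl on this aromatic carbon gives a number 3.90 log units higher from compound 3 to compound 4 (beyond the scatter) and, against the smaller methyl, a number 1.60 log units higher from compound 1 to compound 4 (beyond the scatter) in this assay. The earlier compounds shown here showed only a fall at this position, but it now reads in both directions, and the three groups on the shared core rank methylsulfonyl, methyl, tert-butyl from lowest to highest. Nothing available explains this order. Going by these compounds, whether an amine or a carboxylic acid at this carbon would rank below methylsulfonyl remains open. So does whether the same ranking would hold on the core of compound 2.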